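The source may report more compounds than this note shows. Statements on the series, on what has been measured and on what is new or still open speak of the compounds shown alone.

Measured compounds and their values in a functional assay on MCF7 cells (Homo sapiens) for antiproliferative activity, read by sulforhodamine B assay, with a stated time of 48 h; on this read-out lower numbers stand for stronger inhibition and higher numbers for weaker inhibition:

Compound 1 `O=C1NCCN1c1ccc(S(=O)(=O)Nc2ccc(F)cc2)cc1` gives 690 nM.
Compound 2 `Cc1cc(C)cc(NS(=O)(=O)c2ccc(N3CCNC3=O)cc2)c1` gives 100 nM.
Compound 3 `O=C1NCCN1c1ccc(S(=O)(=O)Nc2ccc(Br)cc2)cc1` gives 240 nM.

All three share a core that carries a sulfonamide, and they differ only in the aromatic group attached to the sulfonamide nitrogen. Compound 3 stands second highest of the three numbers: compound 2 lies nearest, a 2.4-fold higher number from compound 2 to compound 3 (0.38 log units; beyond the scatter), while compound 1 lies furthest, a 2.9-fold lower number from compound 1 to compound 3 (0.46 log units; beyond the scatter). The largest step among the measured compounds is a 6.9-fold lower number from compound 1 to compound 2 (0.84 log units; beyond the scatter), and all three steps are modest.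

Compound 4 `COc1cccc(NS(=O)(=O)c2ccc(N3CCNC3=O)cc2)c1` is the next member of the series, and it differs from compound 3 in one place: 3-methoxyphenyl in place of 4-bromophenyl on a sulfonamide nitrogen. Going by the values given here, no measured pair shows this particular exchange, so the three steps among the aromatic groups on the sulfonamide nitrogen are the only guide. Among the compounds with values here, they show that swapping one aromatic group for another moves the number only modestly in either direction, with the 3,5-dimethylphenyl compound giving the lowest number so far. A modest step is therefore expected here, more likely toward a lower number, and the expected step from compound 3 is a 1.3-fold lower number from compound 3 to compound 4 (0.12 log units; within the scatter). Compound 4 is estimated to give 180 nM in this assay, with a range from 70 nM to 450 nM.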

Compound 4, half-maximal inhibitory concentration: 120 nM
Estimate against measurement, compound 4: 1.5-fold (0.18 log units) above; low and high end bracket the measured number.
By their numbers in this assay, from the lowest: compounds 2, 4 and 3 (each within the scatter of the next, the first and the last beyond it); then compound 1.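

Exchanging 4-bromophenyl for 3-methoxyphenyl on the sulfonamide nitrogen gives a 2.0-fold lower number from compound 3 to compound 4 (0.30 log units; within the scatter), and exchanging 3,5-dimethylphenyl for the same group gives a 1.2-fold higher number from compound 2 to compound 4 (0.08 log units; within the scatter). Compound 4 therefore cannot be told apart from either compound, even though the step between those two lies beyond the scatter. The step from the 4-fluorophenyl compound, a 5.8-fold lower number from compound 1 to compound 4 (0.76 log units; beyond the scatter), is the only clear one, which shows that this position can carry a group containing oxygen, an atom absent from the groups in compounds 1, 2 and 3, and still stay well clear of compound 1; nothing among the available data explains these differences.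

As far as these compounds go, all four groups here are substituted phenyl rings, so it remains open how this position would respond to an amine or a carboxylic acid on the ring, or to a cyclohexyl ring in place of the phenyl ring. The compounds shown also hold no 4-methoxyphenyl partner for compound 4, so they cannot say whether the placing of the methoxy group on the ring matters.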